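The source may hold more compounds than are shown below. What is called first, only, known or untested is meant among the compounds shown, and "the series" means these compounds.

Compound 2 `CS(=O)(=O)c1ccc(F)cc1NCC1=NCCN1` has been tested in an assay on CHO cells for binding affinity to Alpha-2B adrenergic receptor (Homo sapiens), read by radioligand binding (a higher number here means a weaker inhibitor, a lower number a stronger inhibitor), but only a limit is known there: compound 2 gives < 6310 nM. Compound 1 `CSc1ccc(C)cc1NCC1=NCCN1` gives a number in this assay, 977 nM. Of the two values shown, one sits at a limit (the limit of < 6310 nM in this assay, at which 1 of the 2 values shown sits). The step to compound 3 `Cc1ccc(S(C)(=O)=O)c(NCC2=NCCN2)c1` replaces (methyl in place of fluoro on an aromatic carbon), a methyl in place of fluoro on an aromatic carbon. Within the data shown here, no measured pair shows this change, so the expected step from compound 2 to compound 3, a step that the limit leaves unreadable from compound 2 to compound 3, is estimated as modest in this assay, if anything toward stronger binding. Compound 3 is expected to give about 3000 nM, within 800 nM to 12000 nM.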

Compound 3, inhibition constant: < 6310 nM
Compound 3: a limit, no number; the forecaster's own chance of this, stated with the estimate: 35%; the middle value lies beyond the limit too.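

In this assay compound 3 gives < 6310 nM, a limit and not a number, so no step can be read from compound 3 to compound 1 or compound 2. On these data alone, what the methyl in place of fluoro on an aromatic carbon does to binding stays open, as does how far compound 2 and compound 3 lie from compound 1.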